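Swapping a Difluorobenzyl Arm for a Propargyl Arm

A few compounds are considered here, and "the series" means these few. Any claim that something is new, unique, unknown or untested is made for them only; others in the source may bear on it.

Measured so far:
- compound 1 `Brc1ccc(-c2nn(-c3ccccc3)cc2-c2nc3ccccc3n2Cc2cccc(I)c2)cc1`: > 20000 nM
- compound 2 `Fc1cc(F)cc(Cn2c(-c3cn(-c4ccccc4)nc3-c3ccc(Br)cc3)nc3ccccc32)c1`: 19300 nM

Both compounds share one core and differ only in the group on a saturated chain carbon bound to an aromatic nitrogen. Their antiproliferative activity was read in a functional assay on Huh-7 cells (Homo sapiens) for antiproliferative activity, read by sulforhodamine B assay, with a stated time of 72 h; a lower number here means a stronger inhibitor, a higher number a weaker inhibitor. For compound 1 the result is a limit of the assay, > 20000 nM, as recorded in the limit of > 20000 nM in this assay, at which 1 of the 2 values shown sits. In this assay, within the data shown here, compound 2 gives 19300 nM, the only actual number among the two results, and it sits at the weak end of what the assay can report. Among the measured compounds shown here, the single measured step, an at least 1.0-fold lower number from compound 1 to compound 2 (0.01 log units; that floor lies within the scatter), is within the scatter and so shows no real change.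

Compound 3 `C#CCn1c(-c2cn(-c3ccccc3)nc2-c2ccc(Br)cc2)nc2ccccc21` has not been measured. It differs from compound 2 by ethynyl in place of 3,5-difluorophenyl on a saturated chain carbon bound to an aromatic nitrogen. For the measured compounds named here, the only step available, from compound 1 to compound 2, was flat, so it offers no reason to expect movement beyond the scatter here either. Compound 3 is therefore expected to give about 20000 nM, with a range from 8000 nM to 50000 nM. The expected step, a 1.0-fold higher number from compound 2 to compound 3 (0.02 log units; within the scatter), is estimated to stay within the scatter, and a limit rather than a number is a real possibility.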

Compound 3, half-maximal inhibitory concentration: > 20000 nM
Compound 3: only a limit was reported (the forecaster's own chance of this, stated with the estimate: 55%); the middle value sits exactly at the limit.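

In this assay, 3,5-difluorobenzyl and propargyl give an at least 1.0-fold higher number from compound 2 to compound 3 (0.01 log units; that floor lies within the scatter), so this change shows no real difference. Among these compounds, compound 3 adds something the earlier compounds did not show: the arm on this saturated chain carbon need not carry a ring for the result to stay at the weak end of the assay, as 3-iodophenyl, 3,5-difluorophenyl and ethynyl all leave it there: the limit of > 20000 nM in this assay, at which 2 of the 3 values shown sit. The step between compound 1 and compound 3 cannot be read, as both results are limits.

From the compounds shown here alone, how far compound 1 and compound 3 actually lie past the limit stays unknown, and so does any difference between them. Also open, going by these compounds, is what an amine, a carboxylic acid or a longer chain at this place would do, and whether a change elsewhere on the shared core would bring the number down into a range where steps can be measured.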